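This account rests on a few compounds, and the source may have more. Where it says the series, first, only, none or still open, it means among the compounds named here.

Of the compounds shown here, three have been measured in a functional assay on MDA-MB-231 cells (Homo sapiens) for inhibition, read by MTT assay, with a stated time of 24 h, tested at 100 uM; on this read-out higher numbers stand for more inhibition at the one concentration tested (going by the name of the read-out) and lower numbers for less inhibition. Compound 1 `CCCCCc1nnc(-c2ccc(O[C@@H]3O[C@H](COC(C)=O)[C@@H](OC(C)=O)[C@H](OC(C)=O)[C@H]3OC(C)=O)cc2)o1` gives 21.5%. Compound 2 `COc1ccc(/C=N/NC(=O)c2ccc(O[C@@H]3O[C@H](CO)[C@@H](O)[C@H](O)[C@H]3O)cc2)cc1` gives 11.3%, and compound 3 `O=C(N/N=C/c1cccc([N+](=O)[O-])c1)c1ccc(O[C@@H]2O[C@H](CO)[C@@H](O)[C@H](O)[C@H]2O)cc1` gives 6.23%. Among these three numbers compound 2 stands second highest: compound 3 is its nearest neighbour, lower but within the usual scatter, while compound 1 lies above it by more than the scatter.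

Compound 4 `Cc1ccc(/C=N/NC(=O)c2ccc(O[C@@H]3O[C@H](CO)[C@@H](O)[C@H](O)[C@H]3O)cc2)cc1` is compound 2 with a single change: methyl in place of methoxy on an aromatic carbon. Going by the values given here, no measured pair of compounds differs in exactly this way, so the expectation must rest on the one step that is known on this part of the molecule, a number 5.1 percentage points lower from compound 2 to compound 3 (within the scatter). That step exchanged the whole ring group attached to the carbon with a double bond to nitrogen, and even so the read-out moved only within the scatter. A smaller exchange of one substituent on the ring is therefore expected to move it no more. The expected step of a number 0.3 percentage points lower from compound 2 to compound 4 (within the scatter) is none beyond the scatter. Compound 4 is estimated at 11%, with a range from 3% to 20%.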

Compound 4, a percentage reported as inhibition, at one concentration (the size of the read-out at that concentration, not a potency): 9.28%
Compound 4: the middle estimate sits 1.7 percentage points above what was measured, and the stated range covers the measured number.
By their numbers in this assay, from the lowest: compounds 3, 4 and 2 (each within the scatter of the next); then compound 1.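

In this assay, 4-methylphenyl in place of 4-methoxyphenyl gives a number 2 percentage points lower from compound 2 to compound 4 (within the scatter) and so shows that, at this place para to a large group, losing the oxygen of the methoxy does not move the read-out beyond the scatter. Setting 4-methylphenyl in place of 3-nitrophenyl on the carbon with a double bond to nitrogen gives a number 3.1 percentage points higher from compound 3 to compound 4 (within the scatter) and so the three ring groups seen here cannot be told apart in this read-out. Nothing available explains why these numbers stay so close.

Still open, from the compounds shown here alone, is whether an amine, a carboxylic acid or a longer chain in place of the methyl would move the read-out beyond the scatter. Compound 1 differs from these compounds in more than one place, so its number cannot be tied to any single group.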